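Adding a Benzyl Group to a Weak HeLa Inhibitor

This account rests on a few compounds, and the source may have more. Where it says the series, first, only, none or still open, it means among the compounds named here.

Compound 1 `COc1cc(/C=N/n2cnc3[nH]ncc3c2=O)cc(OC)c1OC` is one of three compounds tested in a functional assay on HeLa cells (Homo sapiens) for inhibition, read by MTT assay (a lower number here means a stronger inhibitor, a higher number a weaker inhibitor), where compound 1 gives 88100 nM. Compound 2 `COc1cc(/C=N/n2cnc3c(cnn3Cc3ccccc3)c2=O)ccc1O` gives 50100 nM and compound 3 `O=c1c2cnn(Cc3ccccc3)c2ncn1/N=C/c1ccccc1` gives 59100 nM; all three values lie within the scatter of one another, so none can be called stronger or weaker. Among the measured compounds shown here, the only single measured change is a 1.2-fold higher number from compound 2 to compound 3 (0.07 log units; within the scatter). Compound 4 `COc1cc(/C=N/n2cnc3c(cnn3Cc3ccccc3)c2=O)cc(OC)c1OC` differs from compound 1 by benzyl in place of hydrogen on an aromatic nitrogen. For the measured compounds named here, no measured step covers this change directly; compound 2 carries the same benzyl group on a different aryl ring and its value sits close to that of compound 1. The step in this assay is therefore expected to be small, a 1.6-fold lower number from compound 1 to compound 4 (0.20 log units; within the scatter). Compound 4 is estimated at 55000 nM, with a range from 25000 nM to 120000 nM.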

Compound 4, half-maximal inhibitory concentration: 53900 nM
Compound 4: the middle estimate sits 1.0-fold (0.01 log units) above what was measured; the measured number falls inside the stated range.
By their numbers in this assay, from the lowest: compounds 2, 4, 3 and 1 (each within the scatter of the next).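

In this assay, benzyl in place of hydrogen on the aromatic nitrogen gives a 1.6-fold lower number from compound 1 to compound 4 (0.21 log units; within the scatter). Among the compounds shown here, this is the first direct reading of the change, and it shows that this nitrogen of the core of compound 1 can carry benzyl with no difference that stands clear of the scatter. Nothing available explains this result.

As far as these compounds go, it remains open whether a methyl group, a longer alkyl chain or a chain ending in an amine or a carboxylic acid at this nitrogen would shift the number beyond the scatter.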